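Solubility notes: oxazolidinone series, hydantoin to methanesulfonamide

The source may report more compounds than this note shows. Statements on the series, on what has been measured and on what is new or still open speak of the compounds shown alone.

Measured compounds:
compound 1 `CCN1CCN(C[C@H]2CN(c3ccc(-n4cc(-c5ccccn5)cn4)c(F)c3)C(=O)O2)CC1`, a physicochemical assay for solubility, read by HPLC, with a stated time of 24 h; on this read-out lower numbers stand for lower solubility and higher numbers for higher solubility: 706000 nM
compound 2 `O=C1CNC(=O)N1C[C@H]1CN(c2ccc(-n3cc(-c4ccccn4)cn3)c(F)c2)C(=O)O1`, this assay: 1630000 nM

Compound 2 stands highest of the two numbers in this assay; its nearest neighbour is compound 1, and the step of a 2.3-fold higher number from compound 1 to compound 2 (0.36 log units; beyond the scatter) is modest but beyond the scatter. Compound 3 `CS(=O)(=O)NC[C@H]1CN(c2ccc(-n3cc(-c4ccccn4)cn3)c(F)c2)C(=O)O1` is not yet measured in this assay. It differs from compound 2 as follows: methanesulfonamido in place of 2,5-dioxoimidazolidin-1-yl on a saturated chain carbon bound to a saturated ring carbon. Among the compounds with values here, the only step measured so far, a 2.3-fold higher number from compound 1 to compound 2 (0.36 log units; beyond the scatter), concerns a different change at the same place and does not bear directly on this one. Both the leaving and the entering group are uncharged and carry one hydrogen-bond donor and two acceptors, so no step beyond the scatter is expected; the step of a 1.4-fold lower number from compound 2 to compound 3 (0.13 log units; within the scatter) is the estimate. Compound 3 is therefore expected to give 1200000 nM in this assay, within a range of 400000 nM to 3000000 nM.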

Compound 3, solubility: 2300 nM
Estimate against measurement, compound 3: 520-fold (2.72 log units) above; measured number outside the range, below it.
By their numbers in this assay, from the lowest: compound 3; then compound 1; then compound 2.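

The position matters far more in this assay than the earlier pair suggested: this change gives a 710-fold lower number from compound 2 to compound 3 (2.85 log units; beyond the scatter) even though 2,5-dioxoimidazolidin-1-yl and methanesulfonamido match in net charge and in their hydrogen-bond donor and acceptor counts. Those matching counts therefore do not predict the read-out at this saturated chain carbon bound to a saturated ring carbon. The replacement of 4-ethylpiperazin-1-yl also gives a 310-fold lower number from compound 1 to compound 3 (2.49 log units; beyond the scatter) as a large step, so methanesulfonamido stands apart from both other groups, which differ only modestly from each other.

The compounds shown do not separate the loss of the ring from the entry of sulfur, and an acetamido group, with a carbonyl in place of the sulfonyl unit, would address that question. No available evidence accounts for the size of these steps.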